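The source may report more compounds than this note shows. Statements on the series, on what has been measured and on what is new or still open speak of the compounds shown alone.

Measured in a functional assay on NCI-H1975 cells (Homo sapiens) for antiproliferative activity, read by MTT assay, with a stated time of 48 h; a lower number here means a stronger inhibitor, a higher number a weaker inhibitor:
- compound 1 `CCCc1nc2cc(C(=O)N3CCC4(CC3)CC(=O)N(c3ccc(C(F)(F)F)cc3)C4)cc(C)c2[nH]1`: 270 nM
- compound 2 `O=C(c1ccc2[nH]c(-c3ccccc3)nc2c1)N1CCC2(CC1)CC(=O)N(c1ccc(C(F)(F)F)cc1)C2`: 380 nM

In this assay, compound 2 at 380 nM lies within the scatter of compound 1, so the two values cannot be separated. Compound 3 `CC(C)c1ccc(-c2nc3cc(C(=O)N4CCC5(CC4)CC(=O)N(c4ccc(C(F)(F)F)cc4)C5)ccc3[nH]2)cc1` departs from compound 2 by isopropyl in place of hydrogen on an aromatic carbon, with isopropyl in place of hydrogen on an aromatic carbon, turning phenyl into 4-isopropylphenyl. For the measured compounds named here, no measured pair isolates a change of this kind, so no shift beyond the scatter is expected in this assay. The expected change is small: a 1.1-fold lower number from compound 2 to compound 3 (0.04 log units; within the scatter). For compound 3 the estimated value is 350 nM, with an expected range of 130 nM to 950 nM.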

Compound 3, half-maximal inhibitory concentration: > 10000 nM
Compound 3 gave a limit, no number (the forecaster's own chance of this, stated with the estimate: 3%); middle value at least 28-fold (1.45 log units) from the limit.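

Phenyl to 4-isopropylphenyl gives an at least 26-fold higher number from compound 2 to compound 3 (1.42 log units; beyond the scatter) in this assay, the only change in one place that the series offers so far. The position, on an aromatic carbon para to a large group, is therefore not indifferent to substitution, which compound 1 and compound 2 alone could not show. Compound 3 carries a limit and not a number: the limit of > 10000 nM in this assay, at which 1 of the 3 values shown sits.

As far as these compounds go, whether methyl, an amine or a carboxylic acid at this same place would keep the activity of compound 2 remains open. From the compounds shown here alone, the size of the loss also stays unknown, and no feature of isopropyl can yet be singled out as responsible.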